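From trifluoromethoxy to fluoro: an expected small step

The source may report more compounds than this note shows. Statements on the series, on what has been measured and on what is new or still open speak of the compounds shown alone.

Compound 1 `CC(C)CC1n2cncc2CN(Cc2ccc(OC(F)(F)F)cc2)S1(=O)=O` and compound 2 `COC(C)(C)CC1n2cncc2CN([C@@H](C)c2ccc(Cl)cc2)S1(=O)=O` share a core. In an assay on isolated protein for inhibition of Aromatase (Homo sapiens), tested at 1 uM (a lower number here means less inhibition, a higher number more inhibition at the concentration tested (going by the name of the read-out)), compound 1 gives 13% and compound 2 gives 17%; compound 1 carries the smaller of the two numbers shown, by a gap that lies within the scatter, so neither compound is set apart. Compound 3 `CC(C)CC1n2cncc2CN(Cc2ccc(F)cc2)S1(=O)=O` differs from compound 1 by fluoro in place of trifluoromethoxy on an aromatic carbon. Going by the values given here, no measured pair shows what this change does, so the step of a number 1 percentage points lower from compound 1 to compound 3 (within the scatter) is expected to be none beyond the scatter. Compound 3 is therefore estimated to give 12%, with a range from 0% to 30%.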

Compound 3, a percentage reported as inhibition, at one concentration (the size of the read-out at that concentration, not a potency): 39%
For compound 3 the middle estimate is 27 percentage points below the measured one; the measured number lies above the stated range.
By their numbers in this assay, from the lowest: compounds 1 and 2 (each within the scatter of the next); then compound 3.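

Going by these compounds alone, the single change from trifluoromethoxy to fluoro on this aromatic carbon gives, in this assay, a number 26 percentage points higher from compound 1 to compound 3 (beyond the scatter). This is the first step shown that lies beyond the scatter, and it means the position is not indifferent to the group it carries, which compound 1 and compound 2, differing in more than one place, could not show. Nothing available explains the step.

The compounds shown leave open whether the rise belongs to fluoro itself or to the loss of trifluoromethoxy, as neither plain hydrogen nor a methoxy group at this carbon appears among them. They also leave open whether the same change would act alike with the other side chain and benzylic methyl of compound 2.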